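The compounds below may be only part of what the source reports. "The series", "measured", "known", "first", "only" and "open" are said of these compounds alone.

Compound 1 `CCCCc1ccc2c(c1)C(=O)C(=O)N2` — in a functional assay on K562 cells (Homo sapiens) for antiproliferative activity, read by MTT assay, with a stated time of 48 h (a higher number here means a weaker inhibitor, a lower number a stronger inhibitor), compound 1 gives > 10000 nM, a limit of the assay rather than a number.
Compound 2 `COc1ccc(-c2ccc3c(c2)C(=O)C(=O)N3C)cc1` — in this assay compound 2 gives 4980 nM.

Among the compounds with values here, compound 2 thus holds the only number in this assay; the remaining value is the limit of > 10000 nM in this assay, at which 1 of the 2 values shown sits. Compound 3 `COc1ccc(-c2ccc3c(c2)C(=O)C(=O)N3c2ccc(OC)cc2)cc1` differs from compound 2 by 4-methoxyphenyl in place of methyl on an amide-type nitrogen in a ring. Within the data shown here, no measured pair differing in one place exists here, so the size of this step rests on no comparison; a modest move towards stronger inhibition is expected, as the estimated step of a 1.7-fold lower number from compound 2 to compound 3 (0.22 log units; within the scatter), though none beyond the scatter would not surprise. Compound 3 is expected at 3000 nM, within 800 nM to 12000 nM.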

Compound 3, half-maximal inhibitory concentration: > 10000 nM
Compound 3 ended at the assay's limit; the forecaster's own chance of this, stated with the estimate: 25%; middle value at least 3.3-fold (0.52 log units) from the limit.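

In this assay, 4-methoxyphenyl in place of methyl on this amide-type nitrogen brought no gain, the reading being an at least 2.0-fold higher number from compound 2 to compound 3 (0.30 log units; that floor lies within the scatter). Going by these compounds, only a floor is known, so the real size of the step stays open, and that floor alone does not clear the usual scatter. Compound 3 gives a limit of the assay and not a number: the limit of > 10000 nM in this assay, at which 2 of the 3 values shown sit.

The compounds shown leave open how an ethyl group or a 2-aminoethyl chain on this nitrogen would compare with the methyl of compound 2.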